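The source may hold more compounds than are shown below. What is called first, only, known or untested is meant among the compounds shown, and "the series" means these compounds.

Measured compounds in a functional assay on MCF7 cells (Homo sapiens) for cytotoxicity, read by MTT assay, with a stated time of 24 h; a lower number here means a stronger inhibitor, a higher number a weaker inhibitor:
- compound 1 `Cn1nc(-c2nnc(SCc3c(F)cccc3F)o2)cc1-c1ccc(C(F)(F)F)cc1`: 26200 nM
- compound 2 `Cn1nc(-c2nnc(SCc3ccc(C(F)(F)F)cc3)o2)cc1-c1ccc(C(F)(F)F)cc1`: 15500 nM
- compound 3 `Cn1nc(-c2ccc(C(F)(F)F)cc2)cc1-c1nnc(SCCOc2ccccc2F)o1`: 33300 nM

Compound 3 gives the highest number of the three in this assay. Its gap to compound 1 lies within the scatter, so the two cannot be ordered; only its gap to compound 2 reaches beyond the scatter.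

Compound 4 `Cn1nc(-c2ccc(C(F)(F)F)cc2)cc1-c1nnc(SCc2cccc([N+](=O)[O-])c2)o1` has not yet been measured. It differs from compound 3 at one place: 3-nitrophenyl in place of (2-fluorophenoxy)methyl on a saturated chain carbon bound to a sulfur. For the measured compounds named here, the one measured step that touches the same place is a 1.7-fold lower number from compound 1 to compound 2 (0.23 log units; within the scatter), where one aryl group replaced another on that carbon and the number barely moved. Going by the values given here, the change to compound 4 is larger in kind, since it also shortens the link between the sulfur and the aromatic ring, and no measured pair shows such a shortening, so the evidence is thin.

On that basis compound 4 is expected to stay close to compound 3, with a step of a 1.5-fold lower number from compound 3 to compound 4 (0.18 log units; within the scatter), perhaps a slightly lower number as in compound 2. The estimate for compound 4 in this assay is 22000 nM, with a range from 8000 nM to 60000 nM.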

Compound 4, half-maximal inhibitory concentration: > 100000 nM
Compound 4 was reported as a limit (the forecaster's own chance of this, stated with the estimate: 10%); middle value at least 4.5-fold (0.65 log units) away from the limit.
By their numbers in this assay, from the lowest: compounds 2, 1 and 3 (each within the scatter of the next, the first and the last beyond it). At a limit, above all of these: compound 4.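

In this assay, for the compounds shown here, an at least 3.0-fold higher number from compound 3 to compound 4 (0.47 log units; beyond the scatter) is the first step at this place that reaches beyond the scatter, whereas a 1.7-fold lower number from compound 1 to compound 2 (0.23 log units; within the scatter) stayed within it. Compound 4 stands at a limit of the assay: the limit of > 100000 nM in this assay, at which 1 of the 4 values shown sits.

Compound 1, with 2,6-difluorophenyl on the same carbon, gives 26200 nM, and compound 2, with 4-(trifluoromethyl)phenyl there, gives 15500 nM. So an aryl group on that carbon does not in itself bring the number to the reading of compound 4; what the ring carries counts, at least in compound 4.

The compounds shown leave open whether the nitro group itself or its place on the ring decides this. They also leave open how a 3-aminophenyl, a 3-carboxyphenyl or a 3-nitrophenyl on a longer chain would read here.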